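The compounds below may be only part of what the source reports. "The series", "measured", "known", "first", "only" and "open" are said of these compounds alone.

Measured in a functional assay on BEAS-2B cells (Homo sapiens) for inhibition, read by MTT assay, with a stated time of 72 h; a lower number here means a stronger inhibitor, a higher number a weaker inhibitor
Compound 1 `C=C(c1ccc(F)cc1F)C1COC2(CCCC2)OO1` gives 62600 nM
Compound 2 `C=C(c1ccc(Cl)c(Cl)c1)C1COC(C)(C)OO1` gives > 100000 nM
Compound 3 `C=C(c1ccc(Cl)c(Cl)c1Cl)C1COC(C)(C)OO1` gives 10200 nM

Compound 2 stands at > 100000 nM as a limit of the assay, not as a number. Compound 3, at 10200 nM here, has the lower of the two actual numbers, and compound 1 lies higher at 62600 nM on the same scale, a gap beyond the usual scatter.

Compound 4 `C=C(c1ccc(Cl)cc1Cl)C1COC(C)(C)OO1` differs from compound 3 by one change, hydrogen in place of chloro on an aromatic carbon. For the measured compounds named here, only one measured step bears on this (an at least 9.8-fold lower number from compound 2 to compound 3 (0.99 log units; beyond the scatter)), in which gaining a chloro group lowered the number. That chloro group sits on a different aromatic carbon from the one changing now, so the step is only a rough guide. Losing a chloro group here should still push the number up. In this assay the expected change is a weaker result, beyond the scatter (a 3.9-fold higher number from compound 3 to compound 4 (0.59 log units; beyond the scatter)). The expected value for compound 4 is 40000 nM (estimated range 12000 nM to 100000 nM).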

Compound 4, half-maximal inhibitory concentration: 68600 nM
Compound 4: the middle estimate sits 1.7-fold (0.23 log units) below what was measured; measured number inside the range.
By their numbers in this assay, from the lowest: compound 3; then compounds 1 and 4 (each within the scatter of the next). At a limit, above all of these: compound 2.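

In this assay, replacing this chloro group with hydrogen gives a 6.7-fold higher number from compound 3 to compound 4 (0.83 log units; beyond the scatter), so a chloro group on the aromatic carbon ortho to two chloro groups also matters. The earlier step, an at least 9.8-fold lower number from compound 2 to compound 3 (0.99 log units; beyond the scatter), involved a chloro group on a different aromatic carbon, so two separate positions have now each been tied to a change beyond the scatter. Among these compounds, compound 3, with three chloro groups, has a lower number than either of the two-chloro compounds that differ from it in one place.

On these data alone, whether a methyl or a methoxy group on this same carbon would match the chloro group or behave like hydrogen remains open. The full size of the step between the first pair also remains open because compound 2 stands at a limit: the limit of > 100000 nM in this assay, at which 1 of the 4 values shown sits.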